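The source may report more compounds than this note shows. Statements on the series, on what has been measured and on what is new or still open speak of the compounds shown alone.

Working notes on the series

Two compounds of the set have been run in an ADME assay on BJ cells (Homo sapiens) for antiproliferative activity, with a stated time of 72 h; a higher number here means that more compound is needed for the effect, a lower number that less compound is needed. Compound 1, `COC(=O)c1cc(=O)c2cc(N)ccc2[nH]1`, carries a small core with an ester and an amine. In this assay compound 1 gives only a limit, > 67200 nM, which is one of the two values in view and sits at the limit of > 67200 nM in this assay, at which 1 of the 2 values shown sits. Compound 2, `COc1ccc(-c2cc(=O)c3c(OC)cc(OC)cc3n2S(=O)(=O)c2ccc(C=O)cc2)cc1`, is the sulfonylated member of the set, with a (4-formylphenyl)sulfonyl group. In this assay compound 2 also gives only a limit, > 34400 nM, and it stands at the limit of > 34400 nM in this assay, at which 1 of the 2 values shown sits. Neither value is a number, so no ordering between compound 2 and compound 1 can be drawn; both lie at the edge of what the assay resolves.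

Compound 3, `COc1ccc(-c2cc(=O)c3c(OC)cc(OC)cc3n2S(=O)(=O)c2ccc(C)cc2)cc1`, has not yet been measured. It differs from compound 2 in one place: methyl in place of formyl on an aromatic carbon. Among the compounds with values here, with no measured step in this assay to lean on, the expectation is that the step from compound 2 to compound 3 is none beyond the scatter, a step that the limit leaves unreadable from compound 2 to compound 3. On that basis compound 3 is expected at about 40000 nM, within 15000 nM to 100000 nM, and most likely again reported only as a limit.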

Compound 3, half-maximal effective concentration: > 44800 nM
Compound 3: no number, only a limit; the forecaster's own chance of this, stated with the estimate: 80%; middle value at least 1.1-fold (0.04 log units) away from the limit.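

In this assay compound 3 gives only a limit, > 44800 nM. Compound 2 also gives only a limit, and no step can be read from compound 2 to compound 3 for methyl in place of formyl. The compounds shown leave open whether any change to this series gives an actual number in this assay.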